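The source may report more compounds than this note shows. Statements on the series, on what has been measured and on what is new or still open speak of the compounds shown alone.

Measured so far in an ADME assay on Jurkat cells (Homo sapiens) for cytotoxicity, read by trypan blue exclusion, with a stated time of 24 h; on this read-out lower numbers stand for stronger inhibition and higher numbers for weaker inhibition
compound 1 (`N#C[Se]Cc1ccc([N+](=O)[O-])cc1`) gives 6860 nM
compound 2 (`N#C[Se]Cc1cccc([N+](=O)[O-])c1`) gives 12200 nM
compound 3 (`N#C[Se]Cc1ccccc1[N+](=O)[O-]`) gives 12900 nM

Compound 3 stands within the scatter of both other compounds, so these three nitro compounds show no order in this assay. Compound 4 (`N#C[Se]Cc1ccccc1C#N`) differs from compound 3 in one place, with cyano in place of nitro on an aromatic carbon, ortho to a group of 4 heavy atoms (cyano in place of nitro on an aromatic carbon). Among the measured compounds shown here, no measured pair shows this exchange, so the expectation rests on compound 3 at 12900 nM and on the narrow spread of the three values. No step beyond the scatter is expected in this assay in either direction. The estimated 1.1-fold higher number from compound 3 to compound 4 (0.04 log units; within the scatter) is small. For compound 4 the estimated value is 14000 nM with 7000 nM to 28000 nM as the expected range.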

Compound 4, half-maximal inhibitory concentration: 17100 nM
Compound 4: middle estimate off by 1.2-fold (0.09 log units), on the low side; the measured number falls inside the stated range.
By their numbers in this assay, from the lowest: compounds 1, 2, 3 and 4 (each within the scatter of the next, the first and the last beyond it).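

In this assay, among the compounds shown here, the first direct exchange at this position, a 1.3-fold higher number from compound 3 to compound 4 (0.12 log units; within the scatter) is what cyano in place of nitro gives on this aromatic carbon. For the compounds shown here, at this position, then, nitro can give way to cyano with no step that stands out from the scatter. No supporting measurement bears on this result.

On these data alone, it remains open whether an amine or a carboxylic acid on this carbon would move the number beyond the scatter. As far as these compounds go, the same exchange in compound 1 and compound 2 also remains open.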